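The source may hold more compounds than are shown below. What is called first, only, known or untested is meant among the compounds shown, and "the series" means these compounds.

Compound 1 `CCCC(=O)Oc1ccc2oc(/C=C/[S+](C)[O-])cc(=O)c2c1` gives 2200 nM in a functional assay on A549 cells (Homo sapiens) for cytotoxicity, with a stated time of 48 h (on this read-out higher numbers stand for weaker inhibition and lower numbers for stronger inhibition), and stands lowest of the two numbers, with compound 2 `CC(C)CC(=O)Oc1ccc2oc(/C=C/[S+](C)[O-])cc(=O)c2c1` at 2300 nM nearest to it. The step of a 1.0-fold higher number from compound 1 to compound 2 (0.02 log units; within the scatter) is within the scatter. Compound 3 `C[S+]([O-])/C=C/c1cc(=O)c2cc(OC(=O)C(C)(C)C)ccc2o1` differs from compound 1 by tert-butyl in place of propyl on a carbonyl carbon, a change in the same part of the molecule as the step from compound 1 to compound 2, where added chain carbons left the number unmoved. The step from compound 1 to compound 3 is therefore expected to be a 1.0-fold higher number from compound 1 to compound 3 (0.02 log units; within the scatter), none beyond the scatter. For compound 3 the estimate in this assay is 2300 nM, ranging from 1100 nM to 4800 nM.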

Compound 3, half-maximal inhibitory concentration: 1600 nM
Compound 3: the middle estimate sits 1.4-fold (0.16 log units) above what was measured, and the stated range covers the measured number.
By their numbers in this assay, from the lowest: compounds 3, 1 and 2 (each within the scatter of the next).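

In this assay, tert-butyl on the carbonyl carbon, in place of propyl or of isobutyl, stays within the scatter (a 1.4-fold lower number from compound 1 to compound 3 (0.14 log units; within the scatter); a 1.4-fold lower number from compound 2 to compound 3 (0.16 log units; within the scatter)). The tolerance seen for one added methyl therefore extends to a fully branched group at this position, at least across these three compounds. Nothing available bears on why these groups read alike. On these data alone, how a longer chain, a phenyl ring or an amine on this carbonyl carbon would read remains open. So does whether the shared core alone sets the level.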